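A few compounds are considered here, and "the series" means these few. Any claim that something is new, unique, unknown or untested is made for them only; others in the source may bear on it.

In a functional assay on HL-60 cells (Homo sapiens) for inhibition, read by CCK-8 assay, with a stated time of 48 h (a higher number here means a weaker inhibitor, a lower number a stronger inhibitor), compound 1 `Nc1ccc(Oc2ccccc2-c2ccc(S(=O)(=O)NCCNC(=O)Nc3ccc(Cl)cc3)s2)cc1` gives > 50000 nM, which is a limit of the assay and not a number. For the measured compounds named here, compound 2 `O=C(NCCNS(=O)(=O)c1ccc(-c2ccccc2Oc2ccc([N+](=O)[O-])c([N+](=O)[O-])c2)s1)Nc1ccc([N+](=O)[O-])cc1` gives 340 nM, the only true number so far. Compound 3 `O=C(NCCNS(=O)(=O)c1ccc(-c2ccccc2Oc2ccc([N+](=O)[O-])c([N+](=O)[O-])c2)s1)Nc1ccc(Cl)cc1` differs from compound 2 in one place, with chloro in place of nitro on an aromatic carbon, para to a large group: chloro in place of nitro on an aromatic carbon. Going by the values given here, no measured pair shows this change alone, so the expectation in this assay is only a moderate move toward a weaker inhibitor. The expected change is a 2.4-fold higher number from compound 2 to compound 3 (0.37 log units; beyond the scatter). For compound 3 the estimated value is 800 nM, with an expected range of 200 nM to 3500 nM.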

Compound 3, half-maximal inhibitory concentration: 8100 nM
Beside the measured number, compound 3's estimate is 10-fold (1.01 log units) below it; measured number outside the range, above it.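

In this assay, the group para to a large group matters far more than a single swap could be assumed to show: changing nitro to chloro there gives a 24-fold higher number from compound 2 to compound 3 (1.38 log units; beyond the scatter). Chloro does not end the activity, since the other end of the molecule also counts, with an at least 6.1-fold lower number from compound 1 to compound 3 (0.79 log units; beyond the scatter). That second step rests on a limit, not a true number: the limit of > 50000 nM in this assay, at which 1 of the 3 values shown sits.

Still open, as far as these compounds go, is how an amine or a methoxy group would read at this same place. Also open, from the compounds shown here alone, is whether 4-nitrophenyl in place of 4-chlorophenyl would bring compound 1 within measurable range.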